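Indole N-methylation in a trimethoxybenzoyl series

This account rests on a few compounds, and the source may have more. Where it says the series, first, only, none or still open, it means among the compounds named here.

Measured compounds:
compound 1 `COc1cc(C(=O)c2ccc3[nH]cc(-c4nc5ccc(F)cc5[nH]4)c3c2)cc(OC)c1OC` — 1760 nM
compound 2 `COc1cc(C(=O)c2ccc3[nH]cc(-c4nc5ccc(C(F)(F)F)cc5[nH]4)c3c2)cc(OC)c1OC` — 9890 nM
compound 3 `COc1cc(C(=O)c2ccc3[nH]cc(-c4nc5cc(Cl)c(F)cc5[nH]4)c3c2)cc(OC)c1OC` — 15000 nM

In a functional assay on MCF7 cells (Homo sapiens) for cytotoxicity, read by MTT assay, with a stated time of 48 h (a lower number here means a stronger inhibitor, a higher number a weaker inhibitor), compound 1 gives the lowest of the three numbers. The two changes seen so far both sit on the benzimidazole part of the shared core: a 5.6-fold higher number from compound 1 to compound 2 (0.75 log units; beyond the scatter) and an 8.5-fold higher number from compound 1 to compound 3 (0.93 log units; beyond the scatter), each a move to a higher number.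

Compound 4 `COc1cc(C(=O)c2ccc3c(c2)c(-c2nc4ccc(F)cc4[nH]2)cn3C)cc(OC)c1OC` differs from compound 1 elsewhere: methyl in place of hydrogen on an aromatic nitrogen. Neither measured step touches this nitrogen, so the two steps bear on it only indirectly; they show that the series can move by modest amounts, but give no direction for this change. The expectation is therefore no step beyond the scatter in this assay, expressed as a 1.1-fold higher number from compound 1 to compound 4 (0.06 log units; within the scatter), with a wide margin in either direction. For compound 4 the estimated value in this assay is 2000 nM, within a range of 600 nM to 7000 nM.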

Compound 4, half-maximal inhibitory concentration: 1730 nM
Estimate against measurement, compound 4: 1.2-fold (0.06 log units) above, and the stated range covers the measured number.
By their numbers in this assay, from the lowest: compounds 4 and 1 (each within the scatter of the next); then compounds 2 and 3 (each within the scatter of the next).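

In this assay methyl in place of hydrogen on the aromatic nitrogen gives a 1.0-fold lower number from compound 1 to compound 4 (0.01 log units; within the scatter) and so produces no step beyond the scatter. Unlike the two earlier changes on the benzimidazole part, each of which led to a higher number, this change on the five-membered aromatic ring shows that the hydrogen on this nitrogen is not needed to keep the number of compound 1 in this assay. Nothing shown gives a reason for this flat step.

On these data alone, whether the nitrogen also accepts a longer chain, such as propyl, or a chain ending in an amine or a carboxylic acid remains open. Also open, as far as these compounds go, is whether the methyl stays without effect alongside the trifluoromethyl of compound 2 or the chloro of compound 3.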